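Extending the Chain on Compound 2

A few compounds are considered here, and "the series" means these few. Any claim that something is new, unique, unknown or untested is made for them only; others in the source may bear on it.

Of the compounds shown here, two have been measured in a functional assay on the whole organism with Canis familiaris (Canis lupus familiaris) as the target, at a dose of 2 mg/kg by the intravenous route; a higher number here means a stronger effect of the compound at the dose given, a lower number a weaker effect. Compound 1 `Cc1ccn2c(C)c(C)nc2c1OCc1ccccc1` gives 70% in this assay, while compound 2 `Cc1nc2c(OCc3ccccc3)cccn2c1N` gives 97% in this assay, the higher of the two numbers and a gap beyond the usual scatter. Compound 3 `CCCCc1nc2c(OCc3ccccc3)cccn2c1N` differs from compound 2 in one place: propyl in place of hydrogen on a saturated chain carbon bound to an aromatic carbon. For the measured compounds named here, no measured pair shows what lengthening this chain does, and compound 2 already stands close to complete inhibition, so the step from compound 2 to compound 3 is expected to be small, a number 9 percentage points lower from compound 2 to compound 3 (within the scatter), within the scatter or slightly downward. Compound 3 is therefore estimated at 88%, expected to lie between 70% and 100%.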

Compound 3, a percentage reported as inhibition, in the whole organism at one dose (the size of the read-out at that dose, not a potency): 45%
Beside the measured number, compound 3's estimate is 43 percentage points above it; the measured number lies below the stated range.
By their numbers in this assay, from the lowest: compound 3; then compound 1; then compound 2.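

For the compounds shown here, the saturated chain carbon bound to an aromatic carbon proves sensitive in this assay: propyl in place of hydrogen, which reads as methyl to butyl, brings a number 52 percentage points lower from compound 2 to compound 3 (beyond the scatter), the first step between compounds that differ in one place. At this dose, the longer chain therefore costs much of the effect. Nothing available explains this loss.

The compounds shown leave open whether ethyl or propyl in place of the methyl of compound 2 would keep the effect. They also leave open whether an amine or a carboxylic acid at the end of the butyl chain would restore it.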